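The source may report more compounds than this note shows. Statements on the series, on what has been measured and on what is new or still open speak of the compounds shown alone.

Values measured in a functional assay on CRL2813 cells (Homo sapiens) for cytotoxicity, read by sulforhodamine B assay, with a stated time of 5 days; a lower number here means a stronger inhibitor, a higher number a weaker inhibitor:

- compound 1 `O=C(Nc1ccc(I)cc1)N[C@H]1CC[C@H](Oc2ccc(F)cc2)CC1`: 10200 nM
- compound 2 `O=C(Nc1cccc(F)c1)N[C@H]1CC[C@H](Oc2ccc(F)cc2)CC1`: 8300 nM
- compound 3 `COc1cccc(NC(=O)N[C@H]2CC[C@H](Oc3ccc(F)cc3)CC2)c1`: 14000 nM

These three compounds share a core and differ only in the aromatic group on an amide-type nitrogen. Compound 3 stands level with the other two, since its gaps to them are no larger than the usual scatter: a 1.4-fold higher number from compound 1 to compound 3 (0.14 log units; within the scatter), and a 1.7-fold higher number from compound 2 to compound 3 (0.23 log units; within the scatter). The remaining pair behaves the same way: a 1.2-fold lower number from compound 1 to compound 2 (0.09 log units; within the scatter).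

Compound 4 `COc1ccccc1NC(=O)N[C@H]1CC[C@H](Oc2ccc(F)cc2)CC1` has the same atoms as compound 3, joined differently, with 2-methoxyphenyl in place of 3-methoxyphenyl on an amide-type nitrogen. All three measured steps change this same group, and none of them leaves the scatter. None of them tests 2-methoxyphenyl directly, however, so the range must stay wide. Going by the values given here, no real step is therefore expected in this assay. The expected step is a 1.2-fold lower number from compound 3 to compound 4 (0.07 log units; within the scatter). For compound 4 the estimated value is 12000 nM, with an expected range of 6000 nM to 25000 nM.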

Compound 4, half-maximal inhibitory concentration: > 20000 nM
Compound 4: a limit, no number; the forecaster's own chance of this, stated with the estimate: 8%; middle value at least 1.6-fold (0.22 log units) from the limit.
By their numbers in this assay, from the lowest: compounds 2, 1 and 3 (each within the scatter of the next). At a limit, above all of these: compound 4.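

In this assay, compound 4 is read only as a limit, not as a number: the limit of > 20000 nM in this assay, at which 1 of the 4 values shown sits. Changing 3-methoxyphenyl to 2-methoxyphenyl gives an at least 1.4-fold higher number from compound 3 to compound 4 (0.15 log units; that floor lies within the scatter), so this floor does not by itself separate the two arrangements of the same atoms. Going by these compounds alone, the comparison with 3-fluorophenyl gives an at least 2.4-fold higher number from compound 2 to compound 4 (0.38 log units; beyond the scatter), while the one with 4-iodophenyl gives an at least 1.9-fold higher number from compound 1 to compound 4 (0.29 log units; that floor lies within the scatter), so 2-methoxyphenyl is the first group on this amide-type nitrogen to stand clear of another, though only of 3-fluorophenyl.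

As far as these compounds go, the true value of compound 4 stays unknown, and with it the full size of all three steps. From the compounds shown here alone, it is also open whether a 2-aminophenyl or 2-ethoxyphenyl group on this nitrogen would read like compound 4 or like compounds 1, 2 and 3.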